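Methyl on the anilino ring of compound 2

This account rests on a few compounds, and the source may have more. Where it says the series, first, only, none or still open, it means among the compounds named here.

The three measured compounds share one core. Compound 1 `CCN(CC)CN1C(=O)/C(=N/NC(N)=S)c2ccccc21` gives 121000 nM in a functional assay on L1210 cells (Mus musculus) for inhibition, read by cell counting, with a stated time of 48 h; on this read-out lower numbers stand for stronger inhibition and higher numbers for weaker inhibition. Compound 2 `CCN(CC)CN1C(=O)/C(=N/NC(=S)Nc2ccccc2)c2cc(Cl)ccc21` gives 49000 nM in this assay, and compound 3 `CCN(CC)CN1C(=O)/C(=N/NC(=S)Nc2ccccc2)c2ccccc21` gives 13000 nM. Compound 2 thus holds the second highest of the three numbers, nearest to compound 1 and furthest from compound 3, the latter gap being a 3.8-fold lower number from compound 2 to compound 3 (0.58 log units; beyond the scatter).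

Compound 4 `CCN(CC)CN1C(=O)/C(=N/NC(=S)Nc2ccc(C)cc2)c2cc(Cl)ccc21` differs from compound 2 in one place: methyl in place of hydrogen on an aromatic carbon. The measured steps cover other changes. Phenyl in place of hydrogen on an amide-type nitrogen gave a 9.3-fold lower number from compound 1 to compound 3 (0.97 log units; beyond the scatter). Hydrogen in place of chloro on an aromatic carbon gave a 3.8-fold lower number from compound 2 to compound 3 (0.58 log units; beyond the scatter). Among the compounds with values here, neither step alters the anilino ring itself, so no measured step bears directly on the change to compound 4, and the chloro that distinguishes compound 2 from compound 3 remains in compound 4.

Within the data shown here, with no directly relevant step, the expectation for compound 4 in this assay is a step of no change at the digits printed from compound 2 to compound 4 (within the scatter), which is none beyond the scatter. Compound 4 is therefore estimated at 49000 nM, within a range from 18000 nM to 130000 nM.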

Compound 4, half-maximal inhibitory concentration: 9500 nM
For compound 4 the middle estimate is 5.2-fold (0.71 log units) above the measured one, and the stated range ends above it.
By their numbers in this assay, from the lowest: compounds 4 and 3 (each within the scatter of the next); then compound 2; then compound 1.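

In this assay the anilino ring proves responsive to substitution: going from phenyl to 4-methylphenyl, para to a large group and with the chloro of compound 2 kept, gives a 5.2-fold lower number from compound 2 to compound 4 (0.71 log units; beyond the scatter). Within the data shown here, the earlier steps touched only the amide-type nitrogen and the chloro position, so this is the first sign that this ring carbon can move the read-out, and a single added carbon is enough to do so. No measurement at hand accounts for the size or the direction of this step.

The compounds shown leave open whether the methyl gives a similar step on the chloro-free core of compound 3. They also leave open how a longer chain such as ethyl, a methoxy group, an amine or a carboxylic acid would read at this same ring carbon.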